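Swapping the two-position chain of a benzyl purine core

The source may hold more compounds than are shown below. What is called first, only, known or untested is meant among the compounds shown, and "the series" means these compounds.

Within the data shown here, compound 1 `CCCCc1nc(N)c2nc(O)n(Cc3ccccc3)c2n1` is the lowest of the three numbers so far: in a functional assay (spleen, spleen) for activation, with Mus musculus as the target (on this read-out lower numbers stand for an effect already at smaller amounts and higher numbers for an effect only at larger amounts of compound), compound 1 gives 0.03 uM. Compound 2 `Cc1ccc(Cn2c(O)nc3c(N)ncnc32)cc1` gives 10 uM in this assay, and compound 3 `COc1ccc(Cn2c(O)nc3c(N)ncnc32)cc1` gives 10 uM. Among the measured compounds shown here, the only measured step, no change at the digits printed from compound 2 to compound 3 (within the scatter), concerns the benzyl ring and says nothing about the chain on the core. Compound 4 `CCCNc1nc(N)c2nc(O)n(Cc3ccccc3)c2n1` differs from compound 1 by propylamino in place of butyl on an aromatic carbon. For the measured compounds named here, no measured pair mirrors this change, so the expectation rests on compound 1 alone and is loose. A small loss is expected, a 3.3-fold higher number from compound 1 to compound 4 (0.52 log units; beyond the scatter), with the outcome for compound 4 estimated at 0.1 uM, within 0.01 uM to 1 uM.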

Compound 4, minimum effective concentration: 0.1 uM
Estimate against measurement, compound 4: no gap at the digits printed; the measured number falls inside the stated range.
By their numbers in this assay, from the lowest: compound 1; then compound 4; then compounds 2 and 3 (each within the scatter of the next).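

In this assay, propylamino in place of butyl gives a 3.3-fold higher number from compound 1 to compound 4 (0.52 log units; beyond the scatter) and the loss is modest. The aromatic carbon between two ring nitrogen atoms therefore tolerates a chain that brings in a hydrogen-bond donor and acceptor, with the same number of heavy atoms, while most of the effect of compound 1 is kept. No measurement available here explains this modest loss.

From the compounds shown here alone, it remains open whether the step follows from the linking nitrogen or from the shorter carbon chain. A butylamino or a propyl chain at this position would separate the two.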